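The compounds below may be only part of what the source reports. "The series", "measured", "known", "first", "only" and "open" are said of these compounds alone.

Measured compounds:
- Compound 1 `CC(C)n1cc(S(=O)(=O)c2ccc(CNC(=O)N3Cc4ccncc4C3)cc2)cn1`: in an assay on isolated protein for inhibition of Nicotinamide phosphoribosyltransferase (Homo sapiens), read by mass spectrometry, with stated times of 15 min and 30 min (a lower number here means a stronger inhibitor, a higher number a weaker inhibitor), compound 1 gives 20 nM.
- Compound 2 `CCC(=O)N1CCC(S(=O)(=O)c2ccc(CNC(=O)N3Cc4ccncc4C3)cc2)CC1`: in this assay compound 2 gives 27 nM.

Among the compounds with values here, compound 2 holds the higher of the two numbers so far, with compound 1 as its only neighbour, and the step of a 1.4-fold higher number from compound 1 to compound 2 (0.13 log units; within the scatter) lies within the scatter, so the two compounds cannot be set in order. Within the data shown here, that single step is also the only measured change at the sulfonyl sulfur, and it is small.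

Compound 3 `O=C(NCc1ccc(S(=O)(=O)N2CC3(CCOCC3)C2)cc1)N1Cc2ccncc2C1` has not yet been measured in this assay. It differs from compound 2 by a group of 9 heavy atoms (7 carbon, 1 nitrogen, 1 oxygen; one four-membered non-aromatic ring with 1 hetero atom, one six-membered non-aromatic ring with 1 hetero atom) in place of a group of 10 heavy atoms (8 carbon, 1 nitrogen, 1 oxygen; one six-membered non-aromatic ring with 1 hetero atom), on a sulfonyl sulfur. Among the measured compounds shown here, the one step that bears on this position, a 1.4-fold higher number from compound 1 to compound 2 (0.13 log units; within the scatter), showed that swapping one group for another on that sulfur left the number essentially unchanged, so the expectation is a step of no more than the scatter in this assay, with no clear direction; the group entering in compound 3 has no measured precedent, so the range is kept wide. Compound 3 is therefore estimated at 40 nM, between 12 nM and 130 nM. That expected estimate corresponds to a step of a 1.5-fold higher number from compound 2 to compound 3 (0.17 log units; within the scatter).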

Compound 3, half-maximal inhibitory concentration: 20 nM
Estimate against measurement, compound 3: 2.0-fold (0.30 log units) above; the measured number falls inside the stated range.
By their numbers in this assay, from the lowest: compounds 1, 3 and 2 (each within the scatter of the next).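

In this assay, the group with a four-membered and a six-membered non-aromatic ring on the sulfonyl sulfur reads the same as the two groups before it within the scatter: the step is a 1.4-fold lower number from compound 2 to compound 3 (0.13 log units; within the scatter), and measured against the five-membered aromatic ring it is no change at the digits printed from compound 1 to compound 3 (within the scatter). The earlier compounds shown here offered a single swap at this position, whereas three differently built groups now stand within the scatter of one another, so for these three compounds the number does not distinguish between them, whether the ring on the sulfur is aromatic or not and whether it stands alone or is part of a two-ring group. No measurement is available that would account for this agreement.

From the compounds shown here alone, all three groups are of similar size, at 8 to 10 heavy atoms, so it remains open whether the number would hold with something much smaller on the sulfur, such as a methyl, or with a group of another kind, such as a carboxylic acid or an amine. The compounds also share everything else in the core, so they say nothing about whether this tolerance would persist if another part of the molecule were changed.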